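The source may report more compounds than this note shows. Statements on the series, on what has been measured and on what is new or still open speak of the compounds shown alone.

Measured compounds:
compound 1, `COc1cccc(-c2cc3[nH]nc(N)c3c(=O)[nH]2)c1`, 49%
compound 2, `Cc1cc2[nH]nc(N)c2c(N2CCCCC2)n1`, 87%
compound 3, `COc1cccc(-c2cc3c(c(N)nn3C)c(=O)[nH]2)c1`, 2%

All three were run in an assay on isolated protein for inhibition of ribosomal protein S6 kinase alpha-5 (Homo sapiens), read by mobility shift assay, tested at 30 uM; on this read-out lower numbers stand for less inhibition and higher numbers for more inhibition at the one concentration tested (going by the name of the read-out). Compound 2 gives the highest of the three numbers, and its gap to compound 1 as well as to compound 3 lies beyond the scatter. Compound 1 and compound 3 share a core and differ in one place, (methyl in place of hydrogen on an aromatic nitrogen). That change gives a number 47 percentage points lower from compound 1 to compound 3 (beyond the scatter). How the core of compound 2 differs from the core of compound 1 is not broken down here.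

Compound 4, `Cc1cc2c(c(N)nn2C)c(N2CCCCC2)n1`, is not yet measured. It differs from compound 2 by methyl in place of hydrogen on an aromatic nitrogen. The place is described in the same words for both pairs, so this is the same change carried onto the core of compound 2. Among the compounds with values here, only one measured instance of it exists, and compound 2 starts from a higher number than compound 1 did. If the change carries over, a step of a number 49 percentage points lower from compound 2 to compound 4 (beyond the scatter) is expected in this assay. Within the data shown here, compound 4 is expected to give about 38%, within a range from 8% to 70%, resting on the single precedent of a number 47 percentage points lower from compound 1 to compound 3 (beyond the scatter).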

Compound 4, a percentage reported as inhibition, at one concentration (the size of the read-out at that concentration, not a potency): 7%
Compound 4: middle estimate off by 31 percentage points, on the high side; measured number outside the range, below it.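

In this assay, methyl in place of hydrogen on an aromatic nitrogen gives a lower number on both cores, and the new step is a number 80 percentage points lower from compound 2 to compound 4 (beyond the scatter). The direction of the change carries from one core to the other, but its size does not: the same change on two cores in this assay, a number 47 percentage points lower (beyond the scatter) from compound 1 to compound 3 and a number 80 percentage points lower (beyond the scatter) from compound 2 to compound 4, 33 percentage points apart, beyond the scatter of two such steps

Two cores are a thin base, and they do not show what in a core sets the size of the step; each number is also a percentage at one concentration rather than a potency, so neither step translates into a change in potency.

Still open, on these data alone, is whether a larger group on that aromatic nitrogen, such as ethyl or a longer chain, or a chain ending in an amine or a carboxylic acid, gives a step like that of methyl. Also open, as far as these compounds go, is whether the direction holds on a third core, and how far the size of the step depends on the core that carries it.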